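The compounds below may be only part of what the source reports. "The series", "measured", "known", "first", "only" and "open" are said of these compounds alone.

Measured in a functional assay on MDA-MB-231 cells (Homo sapiens) for cytotoxicity, read by MTT assay, with a stated time of 72 h; on this read-out higher numbers stand for weaker inhibition and lower numbers for stronger inhibition:
- compound 1 `CN(C)Cc1ccc2nc(NC(=O)N/N=C/c3cn(Cc4ccccc4Cl)c4ccccc34)sc2c1` gives 1180 nM
- compound 2 `CC1CCN(Cc2ccc3nc(NC(=O)N/N=C/c4cn(Cc5ccc(Cl)cc5Cl)c5ccccc45)sc3c2)CC1` gives 3140 nM
- compound 3 `CN(C)Cc1ccc2nc(NC(=O)N/N=C3\C(=O)Nc4ccc(F)cc43)sc2c1` gives "not determined" (no result reported)

Compound 1 holds the lowest of the two numbers available, and the gap up to compound 2 lies beyond the scatter. Compound 4 `CN(C)Cc1ccc2nc(NC(=O)N/N=C/c3cn(Cc4ccc(Cl)cc4)c4ccccc34)sc2c1` has not yet been measured. It carries 4-chlorophenyl in place of 2-chlorophenyl on a saturated chain carbon bound to an aromatic nitrogen in the comparison with compound 1.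

For the measured compounds named here, no two measured compounds differ in one place only, so no direct precedent exists. In this assay a step within the scatter is expected, with no firm direction. The estimate is a 1.1-fold higher number from compound 1 to compound 4 (0.04 log units; within the scatter) as the expected step. For compound 4 the estimated value is 1300 nM with an expected range from 550 nM to 3000 nM as its limits.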

Compound 4, half-maximal inhibitory concentration: 880 nM
For compound 4 the middle estimate is 1.5-fold (0.17 log units) above the measured one; low and high end bracket the measured number.
By their numbers in this assay, from the lowest: compounds 4 and 1 (each within the scatter of the next); then compound 2.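

In this assay, the 4-chlorophenyl in place of 2-chlorophenyl on a saturated chain carbon bound to an aromatic nitrogen gives a 1.3-fold lower number from compound 1 to compound 4 (0.13 log units; within the scatter). For the compounds shown here, this is the first comparison in which only one place differs, and it shows that the two chlorobenzyl groups cannot be told apart on this read-out. Nothing at hand bears on the reason for this.

On these data alone, whether an unsubstituted benzyl or a methoxybenzyl at this place would read the same remains open. So does the effect of a morpholine on the shared core, with the 4-chlorobenzyl group kept.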